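The source may report more compounds than this note shows. Statements on the series, on what has been measured and on what is new or still open speak of the compounds shown alone.

Compound 1 `CCOC(=O)c1nn(-c2ccc(Cl)cc2)c(-c2ccccc2)c1CNC(C)(C)C` and compound 2 `CC(C)(C)NCc1c(C(=O)O)nn(-c2ccc(Cl)cc2)c1-c1ccc(Br)cc1` share a core and were examined in a functional assay on OVCAR-3 cells (Homo sapiens) for inhibition, read by sulforhodamine B assay, with a stated time of 48 h; on this read-out lower numbers stand for stronger inhibition of growth and higher numbers for weaker inhibition of growth. In this assay compound 1 gives > 608000 nM; > 559000 nM (2 entries), which is a limit of the assay and not a number. Compound 2 gives 513000 nM, the only actual number shown. Compound 3 `CC(C)(C)NCc1c(C(=O)O)nn(-c2ccc(Cl)cc2)c1-c1ccccc1` carries hydrogen in place of bromo on an aromatic carbon. For the measured compounds named here, no measured step informs this change, so no shift beyond the usual scatter is expected in this assay. The expected change is a 1.1-fold higher number from compound 2 to compound 3 (0.03 log units; within the scatter). Compound 3 is estimated at 550000 nM, with an expected range of 300000 nM to 900000 nM.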

Compound 3, concentration for 50% growth inhibition: 653000 nM
For compound 3 the middle estimate is 1.2-fold (0.07 log units) below the measured one; low and high end bracket the measured number.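

In this assay the change from 4-bromophenyl to phenyl gives a 1.3-fold higher number from compound 2 to compound 3 (0.10 log units; within the scatter) and so leaves the number unchanged within the scatter. For the compounds shown here, this is the first readable step at this position, an aromatic carbon para to a large group, and it shows that the bromo can be replaced by hydrogen without a shift beyond the scatter. Nothing measured here gives a cause for this step.

Going by these compounds, it remains open whether a methoxy group, an amine or a longer chain at this position would move the number beyond the scatter.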